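Thiosemicarbazone series: chloro to nitro on the aryl ring

The compounds below may be only part of what the source reports. "The series", "measured", "known", "first", "only" and "open" are said of these compounds alone.

Measured compounds:
compound 1 `CC1=CC[C@H](C(C)(C)NC(=S)N/N=C/c2ccccc2Cl)CC1`, 64500 nM
compound 2 `CC1=CC[C@H](C(C)(C)NC(=S)N/N=C/c2cccc(Cl)c2)CC1`, 1400 nM
compound 3 `CC1=CC[C@H](C(C)(C)NC(=S)N/N=C/c2ccccc2[N+](=O)[O-])CC1`, 5000 nM

All three were run in a functional assay on NCI-H460 cells (Homo sapiens) for inhibition, read by sulforhodamine B assay, with a stated time of 48 h; on this read-out higher numbers stand for weaker inhibition of growth and lower numbers for stronger inhibition of growth. Compound 1 and compound 2 share every atom; the difference is 3-chlorophenyl in place of 2-chlorophenyl on a carbon with a double bond to nitrogen, and the step is a 46-fold lower number from compound 1 to compound 2 (1.66 log units; beyond the scatter). Compound 2 stands lowest of the three, with compound 3 nearest and compound 1 furthest.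

The change from compound 1 to compound 3 is nitro in place of chloro on an aromatic carbon, which gave a 13-fold lower number from compound 1 to compound 3 (1.11 log units; beyond the scatter).

The unmeasured compound 4 `CC1=CC[C@H](C(C)(C)NC(=S)N/N=C/c2cccc([N+](=O)[O-])c2)CC1` carries the change nitro in place of chloro on an aromatic carbon relative to compound 2. Among the compounds with values here, this is the same kind of change as the one from compound 1 to compound 3, not the same: there the place is ortho to a large group, here it is meta to a large group. Within the data shown here, only one such step has a measurement, so how far it carries over is uncertain; compound 2 already gives the lowest number of the three, leaving less room for a further drop than compound 1 had.

The step from compound 2 to compound 4 in this assay is expected to be a 1.4-fold lower number from compound 2 to compound 4 (0.15 log units; within the scatter), smaller than the earlier one, because a 13-fold lower number from compound 1 to compound 3 (1.11 log units; beyond the scatter) was taken at a different place. Compound 4 is estimated at 1000 nM, between 250 nM and 4000 nM.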

Compound 4, concentration for 50% growth inhibition: > 100000 nM
Compound 4 was reported as a limit; the forecaster's own chance of this, stated with the estimate: 3%; middle value at least 100-fold (2.00 log units) away from the limit.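

In this assay, nitro in place of chloro on an aromatic carbon, meta to a large group, gives an at least 71-fold higher number from compound 2 to compound 4 (1.85 log units; beyond the scatter), so this change does not carry over from one core to the other with the same direction or size: the same change on two cores in this assay, a 13-fold lower number (1.11 log units; beyond the scatter) from compound 1 to compound 3 and an at least 71-fold higher number (1.85 log units; beyond the scatter) from compound 2 to compound 4, at least 920-fold (2.96 log units) apart, beyond the scatter of two such steps. As far as these compounds go, compound 4 is reported only as a limit, so the true size of this step remains unknown: the limit of > 100000 nM in this assay, at which 1 of the 4 values shown sits. Within the data shown here, the series holds only two such steps, each with chloro at a different place, so the comparison shows that a result for this change at one place cannot be assumed at the other, but it gives no rule for the change and no cause for the reversal.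

Still open, from the compounds shown here alone, is how other groups at these two places would compare with chloro and nitro, for example methyl, methoxy, an amine or a carboxylic acid, and whether any of them would follow the order of compound 1 and compound 2 or that of compound 3 and compound 4. Also open, going by these compounds, is how the parent phenyl, with hydrogen in place of chloro or nitro, would stand against these compounds, which would give each step a common reference.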